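Fluoro on the second phenyl of compound 1

A few compounds are considered here, and "the series" means these few. Any claim that something is new, unique, unknown or untested is made for them only; others in the source may bear on it.

Compound 1, `CC(=O)c1cc(-c2ccccc2)cc2cc(-c3ccccc3)[nH]c12`, stands only at a limit in a functional assay on MCF7 cells (Homo sapiens) for cytotoxicity, read by MTT assay, with a stated time of 2 days; on this read-out lower numbers stand for higher toxicity in this test and higher numbers for lower toxicity in this test. In this assay compound 1 gives > 100000 nM, which is a limit of the assay and not a number. Compound 2, `CC(=O)c1cc(-c2ccc(F)cc2)cc2cc(-c3ccccc3)[nH]c12`, also reaches only a limit. In this assay compound 2 gives > 100000 nM, a limit. Among the measured compounds shown here, compound 3, `COc1ccc(-c2cc(C(C)=O)c3[nH]c(-c4ccccc4)cc3c2)cc1`, is the one member with a read number: in this assay compound 3 gives 47800 nM. Two steps are readable, an at least 2.0-fold lower number from compound 1 to compound 3 (0.32 log units; beyond the scatter) and an at least 2.0-fold lower number from compound 2 to compound 3 (0.32 log units; beyond the scatter), both judged against (the limit of > 100000 nM in this assay, at which 2 of the 3 values shown sit). The remaining step is a step that the two limits leave unreadable from compound 1 to compound 2.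

Compound 4, `CC(=O)c1cc(-c2ccccc2)cc2cc(-c3ccc(F)cc3)[nH]c12`, differs from compound 1 as follows: fluoro in place of hydrogen on an aromatic carbon. The fluoro enters para to a large group, on the second phenyl of the shared core. For the measured compounds named here, the only step of the same kind, that from compound 1 to compound 2, is unreadable between two limits, so no step beyond the scatter is expected in this assay, and compound 4 is expected to sit at or near the same limit. The estimate for compound 4 is 100000 nM, expected between 40000 nM and 300000 nM. The expected step is a number no higher from compound 1 to compound 4 (the limit leaves the size open).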

Compound 4, concentration lethal to 50% of the cells: > 100000 nM
Compound 4: only a limit was reported; the forecaster's own chance of this, stated with the estimate: 70%; the middle value lies on the limit itself.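

In this assay compound 4 gives > 100000 nM, a limit and not a number. No step can be read from compound 1 to compound 4, as both stand at a limit: the limit of > 100000 nM in this assay, at which 3 of the 4 values shown sit.

Going by these compounds, whether fluoro in place of hydrogen changes the read-out at all stays open for compound 2 and compound 4.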